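The compounds below may be only part of what the source reports. "The series", "measured", "known", "first", "only" and "open" are said of these compounds alone.

Compound 1 `CN1/C(=C/C=C/C2=[N+](CCCc3ccccc3)c3ccccc3C2(C)C)C(C)(C)c2ccccc21` gives 96% in an assay for displacement of a labelled ligand from protein arginine N-methyltransferase 1 (Homo sapiens), read by scintillation proximity assay, with stated times of 5 min and 8 min, tested at 30 uM; a lower number here means a weaker effect, a higher number a stronger effect of the compound at the concentration tested
Compound 2 `CC1=[N+](CCCc2ccccc2)c2ccccc2C1(C)C` is reported in this assay as "not active" (no number reported), with no number given

Among the compounds with values here, compound 1 carries the only number in this assay: there compound 1 gives 96%, a near-complete effect at the tested concentration. Compound 2 is the only other entry and stands without a number; in this assay compound 2 is reported as "not active" (no number reported), so nothing about the size of a step between the two can be read from it.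

Compound 3 `CCCC[N+]1=C(/C=C/C=C2/N(C)c3ccccc3C2(C)C)C(C)(C)c2ccccc21` differs from compound 1 in one place: methyl in place of phenyl on a saturated chain carbon, three bonds along the chain from a double-bonded nitrogen in a ring. The change touches only the chain on the double-bonded nitrogen and leaves the rest of the structure of compound 1 untouched. Within the data shown here, no measured pair shows this kind of change, so its size cannot be taken from a measured step. The expectation is that the step of a number 8 percentage points lower from compound 1 to compound 3 (within the scatter) stays within the scatter, or at most a small loss. Compound 3 is therefore estimated at 88% in this assay, with a range from 65% to 99%.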

Compound 3, a percentage reported as inhibition, at one concentration (the size of the read-out at that concentration, not a potency): 32%
Compound 3: middle estimate off by 56 percentage points, on the high side; the whole stated range lies above it.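

In this assay the end of the chain on the double-bonded nitrogen proves not to be a free position: methyl in place of phenyl, read as 3-phenylpropyl to butyl, gives a number 64 percentage points lower from compound 1 to compound 3 (beyond the scatter). The effect does not vanish with the phenyl, however, since compound 3 still gives 32%. Nothing at hand accounts for the size of this loss.

The compounds shown leave open whether a ring is needed at this carbon at all, or whether a longer chain such as hexyl would restore the value of compound 1. Also open, from the compounds shown here alone, is how cyclohexyl, a pyridine ring, an amine or a carboxylic acid at the same place would read out.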